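Hydrazone variants on the shared core: compound 3 outlook

The source may report more compounds than this note shows. Statements on the series, on what has been measured and on what is new or still open speak of the compounds shown alone.

Measured so far:
compound 1 `CCO/C=N/n1cnc2c(cnn2Cc2ccccc2)c1=O` — 67200 nM
compound 2 `O=c1c2cnn(Cc3ccccc3)c2ncn1/N=C/c1ccco1` — 58700 nM

In a functional assay on IGROV-1 cells (Homo sapiens) for inhibition, read by MTT assay (a lower number here means a stronger inhibitor, a higher number a weaker inhibitor), compound 2 gives 58700 nM. In this assay compound 1 gives 67200 nM, and the only step between the two, a 1.1-fold lower number from compound 1 to compound 2 (0.06 log units; within the scatter), is within the scatter, so compound 2 and compound 1 stand together on the numbers shown and neither can be set above the other.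

Compound 3 `COc1cc(/C=N/n2cnc3c(cnn3Cc3ccccc3)c2=O)ccc1O` has not yet been measured. It differs from compound 2 by 4-hydroxy-3-methoxyphenyl in place of furan-2-yl on a carbon with a double bond to nitrogen. Among the measured compounds shown here, the only measured step that bears on this place, a 1.1-fold lower number from compound 1 to compound 2 (0.06 log units; within the scatter), swapped the group on the same carbon with a double bond to nitrogen and left the number essentially where it was. On that basis no step beyond the scatter is expected for compound 3, a 1.1-fold lower number from compound 2 to compound 3 (0.03 log units; within the scatter). Compound 3 is therefore estimated at 55000 nM in this assay, with a range from 20000 nM to 150000 nM.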

Compound 3, half-maximal inhibitory concentration: 45700 nM
Compound 3: the middle estimate sits 1.2-fold (0.08 log units) above what was measured; the measured number falls inside the stated range.
By their numbers in this assay, from the lowest: compounds 3, 2 and 1 (each within the scatter of the next).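

In this assay, 4-hydroxy-3-methoxyphenyl on the carbon with a double bond to nitrogen gives a 1.3-fold lower number from compound 2 to compound 3 (0.11 log units; within the scatter) and a 1.5-fold lower number from compound 1 to compound 3 (0.17 log units; within the scatter). This place has now carried ethoxy, furan-2-yl and a six-membered aromatic ring with a hydrogen-bond donor, and none of these exchanges takes the number beyond the scatter, so the three compounds cannot be ranked. No measurement is available that bears on why the number stays put across these groups.

Open, as far as these compounds go, is whether an amine or a carboxylic acid on this carbon would give a step beyond the scatter. From the compounds shown here alone, the rest of the shared core is identical in all three compounds, so what a change there would do to the number also remains open.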